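Urea in place of the acylsulfonamide on the shared core

The source may hold more compounds than are shown below. What is called first, only, known or untested is meant among the compounds shown, and "the series" means these compounds.

Compound 1 `O=C(NC1CCN(Cc2ccn(-c3ccc(C(F)(F)F)cc3)c2)CC1)NS(=O)(=O)c1ccc(F)cc1` and compound 2 `O=C(NC1CCN(Cc2ccn(-c3ccc(C(F)(F)F)cc3)c2)CC1)N1CCC(c2ccccc2O)CC1` share a core and differ only in the group attached to the carbonyl carbon. Among the measured compounds shown here, in an assay on HEK293 cells for displacement of a labelled ligand from melanin-concentrating hormone receptor 1 (Homo sapiens) (on this read-out lower numbers stand for stronger inhibition and higher numbers for weaker inhibition), compound 1 gives 617 nM, the higher of the two numbers measured so far. Compound 2 gives 36 nM in this assay, and the gap between compound 1 and compound 2 lies beyond the scatter.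

Compound 3 `O=C(NC1CCN(Cc2ccn(-c3ccc(C(F)(F)F)cc3)c2)CC1)N1CC[C@H](O)C1` is not yet measured. It differs from compound 1 in one place: 3-hydroxypyrrolidin-1-yl in place of ((4-fluorophenyl)sulfonyl)amino on a carbonyl carbon. For the measured compounds named here, no step between two measured compounds covers this change, so the expectation rests on the two numbers above. Compound 2 shows that a ring-nitrogen substituent on that carbonyl is compatible with a lower number, but the change in compound 3 is far more limited in extent, so a number as low as that of compound 2 is not assumed. The expected step from compound 1 to compound 3 is a 1.5-fold lower number from compound 1 to compound 3 (0.19 log units; within the scatter), a modest move toward a lower number, close to the edge of the scatter. For compound 3 the estimate in this assay is 400 nM, with a range from 100 nM to 1500 nM.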

Compound 3, half-maximal inhibitory concentration: 125 nM
For compound 3 the middle estimate is 3.2-fold (0.51 log units) above the measured one, within the range that was stated.
By their numbers in this assay, from the lowest: compound 2; then compound 3; then compound 1.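

In this assay the exchange of ((4-fluorophenyl)sulfonyl)amino for 3-hydroxypyrrolidin-1-yl on this carbonyl carbon gives a 4.9-fold lower number from compound 1 to compound 3 (0.69 log units; beyond the scatter) and so moves the number beyond the scatter with a group of fewer heavy atoms in place of the one that leaves. Among the compounds shown here, compound 3 is the only one of the three compounds whose group at this carbonyl carbon has no aromatic ring, so such a ring is not required for a number lower than that of compound 1. No measurement at hand accounts for this step.

Open, on these data alone, is what the hydroxyl contributes, which plain pyrrolidine, or a methoxy group or an amine in place of the hydroxyl, would address. Also open, as far as these compounds go, is how the opposite configuration at the stereocentre of 3-hydroxypyrrolidin-1-yl reads on this carbonyl carbon.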